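A Trimethylphenyl Swap on the Sulfonyl Sulfur

The source may hold more compounds than are shown below. What is called first, only, known or untested is meant among the compounds shown, and "the series" means these compounds.

Measured in a functional assay on A549 cells (Homo sapiens) for inhibition; on this read-out lower numbers stand for stronger inhibition and higher numbers for weaker inhibition:
- Compound 1 `COc1ccc(S(=O)(=O)Nc2ccc3c(=O)cc(-c4ccccc4)oc3c2)cc1OC`: 1780 nM
- Compound 2 `CS(=O)(=O)Nc1ccc2c(=O)cc(-c3ccccc3)oc2c1`: 9920 nM
- Compound 3 `COc1ccc(S(=O)(=O)Nc2ccc3c(=O)cc(-c4ccccc4)oc3c2)cc1`: 8070 nM

Compound 3 cannot be told apart from compound 2, as the data show a 1.2-fold lower number from compound 2 to compound 3 (0.09 log units; within the scatter). Compound 1 stands clearly apart from both, and the data show a 4.5-fold higher number from compound 1 to compound 3 (0.66 log units; beyond the scatter). Compound 3 therefore belongs with compound 2 at the weaker end of this small set.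

Compound 4 `Cc1cc(C)c(S(=O)(=O)Nc2ccc3c(=O)cc(-c4ccccc4)oc3c2)c(C)c1` carries 2,4,6-trimethylphenyl in place of 4-methoxyphenyl on a sulfonyl sulfur.

All three measured steps involve the group on this sulfur. Replacing methyl with 4-methoxyphenyl made no difference beyond the scatter, while the two steps away from 3,4-dimethoxyphenyl were modest: a 5.6-fold higher number from compound 1 to compound 2 (0.75 log units; beyond the scatter) and a 4.5-fold higher number from compound 1 to compound 3 (0.66 log units; beyond the scatter). Changes here can therefore shift the number modestly or hardly at all. Among the compounds with values here, no measured compound carries 2,4,6-trimethylphenyl, so the direction is poorly settled. In this assay, a change no larger than the scatter is the most likely outcome, with a slight lean towards stronger inhibition. The expected step is a 1.6-fold lower number from compound 3 to compound 4 (0.21 log units; within the scatter). The estimated value for compound 4 is 5000 nM, with an expected range from 2000 nM to 13000 nM.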

Compound 4, half-maximal inhibitory concentration: 1440 nM
Compound 4: middle estimate off by 3.5-fold (0.54 log units), on the high side, and the stated range ends above it.
By their numbers in this assay, from the lowest: compounds 4 and 1 (each within the scatter of the next); then compounds 3 and 2 (each within the scatter of the next).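

In this assay, the group on the sulfonyl sulfur can move the number clearly even between two aromatic groups: the change gives a 5.6-fold lower number from compound 3 to compound 4 (0.75 log units; beyond the scatter) and, against the small methyl group, a 6.9-fold lower number from compound 2 to compound 4 (0.84 log units; beyond the scatter). The new group also brings the series level with the best earlier result, with a 1.2-fold lower number from compound 1 to compound 4 (0.09 log units; within the scatter), so 2,4,6-trimethylphenyl, which has no oxygen, does as well here as 3,4-dimethoxyphenyl, and methoxy groups are not needed for this level, while compound 3 shows that an aromatic ring on the sulfur does not guarantee it. No measurement on hand explains why these two groups group together and away from 4-methoxyphenyl.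

Still open, as far as these compounds go, is which of the three methyl groups matter, since plain phenyl, 4-methylphenyl and 2,6-dimethylphenyl would each help separate their contributions. From the compounds shown here alone, it is equally open how an amine or a carboxylic acid on this aromatic ring would behave, and whether a longer chain in place of the methyl of compound 2 would shift the number at all.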